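The compounds below may be only part of what the source reports. "The series", "measured", "known", "first", "only" and "open" are said of these compounds alone.

Working notes on the series. Compound 1 `NNc1nc2c(cnn2-c2ccccc2)c(=O)n1-c1ccccc1` gives 2370 nM in a functional assay on K562 cells (Homo sapiens) for cytotoxicity, read by MTT assay; on this read-out lower numbers stand for higher toxicity in this test and higher numbers for lower toxicity in this test. Compound 2 `O=C(NNc1nc2c(cnn2-c2ccccc2)c(=O)n1-c1ccccc1)c1ccccc1` gives 70 nM in this assay, and compound 3 `COc1ccc(C(=O)NNc2nc3c(cnn3-c3ccccc3)c(=O)n2-c2ccccc2)cc1` gives 50 nM in this assay; compound 3 shows the lowest number of the three, but its gap to compound 2 is within the scatter, so no order between the two is claimed. The steps of a 34-fold lower number from compound 1 to compound 2 (1.53 log units; beyond the scatter) and a 47-fold lower number from compound 1 to compound 3 (1.68 log units; beyond the scatter) are large, whereas the step of a 1.4-fold lower number from compound 2 to compound 3 (0.15 log units; within the scatter) is within the scatter. Compound 4 `O=C(NNc1nc2c(cnn2-c2ccccc2)c(=O)n1-c1ccccc1)c1ccc(Cl)cc1` differs from compound 3 by chloro in place of methoxy on an aromatic carbon. Among the compounds with values here, only the step from compound 2 to compound 3 bears on a change at this carbon, and it stayed within the scatter, so in this assay no step beyond the scatter is expected: a 1.2-fold higher number from compound 3 to compound 4 (0.08 log units; within the scatter). Compound 4 is therefore estimated at 60 nM, with a range from 25 nM to 150 nM.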

Compound 4, half-maximal cytotoxic concentration: 860 nM
Estimate against measurement, compound 4: 14-fold (1.16 log units) below; the measured number lies above the stated range.
By their numbers in this assay, from the lowest: compounds 3 and 2 (each within the scatter of the next); then compound 4; then compound 1.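

The position on the aromatic ring is not indifferent to its substituent in this assay, since chloro gives a 17-fold higher number from compound 3 to compound 4 (1.24 log units; beyond the scatter) and a 12-fold higher number from compound 2 to compound 4 (1.09 log units; beyond the scatter), while methoxy in place of hydrogen stayed within the scatter. Acylation of the amine nitrogen still lowers the number with (4-chlorophenyl)carbonyl, but this is only a 2.8-fold lower number from compound 1 to compound 4 (0.44 log units; beyond the scatter) and is a modest step, unlike the large steps with benzoyl and (4-methoxyphenyl)carbonyl. Nothing available accounts for the chloro result.

On these data alone, whether the higher number is particular to chloro or also holds for fluoro, bromo, an amine or a carboxylic acid at this carbon stays open.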